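Fluoro-to-methoxy change on the shared core, second instance

The source may report more compounds than this note shows. Statements on the series, on what has been measured and on what is new or still open speak of the compounds shown alone.

Measured so far in a functional assay on U-87MG ATCC cells for antiproliferative activity against U-87 MG (Homo sapiens), read by MTT assay, with a stated time of 72 h; on this read-out lower numbers stand for stronger inhibition and higher numbers for weaker inhibition:
Compound 1 `O=C(Nc1ccc(Oc2ccnc3[nH]ccc23)cc1)c1cc2cccnc2n(-c2ccc(F)cc2)c1=O` gives 1360 nM.
Compound 2 `COc1ccc(-n2c(=O)c(C(=O)Nc3ccc(Oc4ccnc5[nH]ccc45)cc3)cc3cccnc32)cc1` gives 2350 nM.
Compound 3 `Cn1ccc2c(Oc3ccc(NC(=O)c4cc5cccnc5n(-c5ccc(F)cc5)c4=O)cc3)ccnc21` gives 2120 nM.

Compound 3 holds the second highest of the three numbers; the gap to compound 2 and the gap to compound 1 both lie within the scatter, so the three compounds cannot be separated on these numbers. Two single changes have been measured: a 1.7-fold higher number from compound 1 to compound 2 (0.24 log units; within the scatter) and a 1.6-fold higher number from compound 1 to compound 3 (0.19 log units; within the scatter), neither beyond the scatter.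

Compound 4 `COc1ccc(-n2c(=O)c(C(=O)Nc3ccc(Oc4ccnc5c4ccn5C)cc3)cc3cccnc32)cc1` differs from compound 3 by methoxy in place of fluoro on an aromatic carbon. Among the compounds with values here, this is the same change as the one from compound 1 to compound 2, now made on the core that carries methyl on the aromatic nitrogen. Within the data shown here, the one measured instance of this change gave a number that was higher but within the scatter, so for compound 4 the expectation in this assay is a step of about the same size and direction, a 1.6-fold higher number from compound 3 to compound 4 (0.21 log units; within the scatter), with no confidence that it clears the scatter. The estimate for compound 4 is therefore 3400 nM, with a range of 1500 nM to 7500 nM.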

Compound 4, half-maximal inhibitory concentration: 5150 nM
The estimate for compound 4 lay 1.5-fold (0.18 log units) below the measured number, and the stated range covers the measured number.
By their numbers in this assay, from the lowest: compounds 1, 3 and 2 (each within the scatter of the next); then compound 4.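

In this assay, the change from 4-fluorophenyl to 4-methoxyphenyl now gives a step beyond the scatter, a 2.4-fold higher number from compound 3 to compound 4 (0.39 log units; beyond the scatter), whereas its earlier instance stayed within the scatter, and the two instances agree in direction: the same change on two cores in this assay, a 1.7-fold higher number (0.24 log units; within the scatter) from compound 1 to compound 2 and a 2.4-fold higher number (0.39 log units; beyond the scatter) from compound 3 to compound 4, 1.4-fold (0.15 log units) apart, within the scatter of two such steps. Methyl in place of hydrogen on the aromatic nitrogen also clears the scatter once the core carries methoxy, at a 2.2-fold higher number from compound 2 to compound 4 (0.34 log units; beyond the scatter), and it too agrees in direction with its earlier instance: the same change on two cores in this assay, a 1.6-fold higher number (0.19 log units; within the scatter) from compound 1 to compound 3 and a 2.2-fold higher number (0.34 log units; beyond the scatter) from compound 2 to compound 4, 1.4-fold (0.15 log units) apart, within the scatter of two such steps. Within the data shown here, on these four compounds, neither change alters the size of the other's step by more than the scatter of two such steps, so the two changes can be read as independent of each other, and no compound here goes against that reading.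

The compounds shown leave open how an amine, a chloro or an ethoxy would read at this aromatic carbon, and whether a longer chain on the aromatic nitrogen would raise the number further. They also leave open what lies behind these steps, since a single cell-based read-out on four compounds gives no cause for either change.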